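Shifting a methyl on the aryltriazole arm

The source may report more compounds than this note shows. Statements on the series, on what has been measured and on what is new or still open speak of the compounds shown alone.

Compound 1 `N#CC1=C(N)Oc2c(c3nc4ccccc4nc3c3ccccc23)C12C(=O)N(Cc1cnnn1-c1cccc(S(N)(=O)=O)c1)c1ccccc12` gives 42500 nM in a functional assay on MCF7 cells (Homo sapiens) for antiproliferative activity, read by MTT assay, with a stated time of 48 h; on this read-out lower numbers stand for stronger inhibition and higher numbers for weaker inhibition. Compound 2 `Cc1ccc(C)c(-n2nncc2CN2C(=O)C3(C(C#N)=C(N)Oc4c3c3nc5ccccc5nc3c3ccccc43)c3ccccc32)c1` reaches only the limit > 50000 nM in this assay, so its standing rests on a limit rather than a number. Going by the values given here, the only measured step, an at least 1.1-fold higher number from compound 1 to compound 2 (0.07 log units; that floor lies within the scatter), touches the same aromatic nitrogen and ends at the limit of > 50000 nM in this assay, at which 1 of the 2 values shown sits. Compound 3 `Cc1cc(C)cc(-n2nncc2CN2C(=O)C3(C(C#N)=C(N)Oc4c3c3nc5ccccc5nc3c3ccccc43)c3ccccc32)c1` carries 3,5-dimethylphenyl in place of 2,5-dimethylphenyl on an aromatic nitrogen. Since the group keeps its size and ring, one expects no step beyond the scatter, a number no higher from compound 2 to compound 3 (the limit leaves the size open). Compound 3 is therefore estimated at 50000 nM, between 20000 nM and 150000 nM, quite possibly again reported only as a limit.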

Compound 3, half-maximal inhibitory concentration: > 50000 nM
Compound 3: no number, only a limit; the forecaster's own chance of this, stated with the estimate: 60%; the middle value lies on the limit itself.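

In this assay compound 3 gives only a limit, > 50000 nM. The shift from 2,5-dimethylphenyl to 3,5-dimethylphenyl therefore cannot be read as a step, as both ends are limits. The one readable step is an at least 1.1-fold higher number from compound 1 to compound 3 (0.07 log units; that floor lies within the scatter), so neither dimethylphenyl arrangement is shown to differ from 3-sulfamoylphenyl beyond the scatter.

As far as these compounds go, what stays open is whether any group on this nitrogen gives a number clearly clear of the limit: the limit of > 50000 nM in this assay, at which 2 of the 3 values shown sit. A phenyl ring bearing an amine or a carboxylic acid would be a further case at this position.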